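Acyclic acetal in place of dioxolane on the thioether chain

This account rests on a few compounds, and the source may have more. Where it says the series, first, only, none or still open, it means among the compounds named here.

Compound 3 `c1ccc(-c2nc(SCC3OCCO3)[nH]c2-c2ccccc2)cc1` gives 530 nM in an assay on microsomes from liver for inhibition of sterol O-acyltransferase 1 (Rattus norvegicus) (a higher number here means a weaker inhibitor, a lower number a stronger inhibitor), the highest of the three numbers measured. Compound 1 `C[C@]1(O)CC(=O)OC(CSc2nc(-c3ccccc3)c(-c3ccccc3)[nH]2)C1` gives 140 nM and compound 2 `CO[C@H]1C[C@H](O)C[C@@H](CSc2nc(-c3ccccc3)c(-c3ccccc3)[nH]2)O1` gives 90 nM; the steps of a 3.8-fold higher number from compound 1 to compound 3 (0.58 log units; beyond the scatter) and a 5.9-fold higher number from compound 2 to compound 3 (0.77 log units; beyond the scatter) both replaced a nine-atom oxygen-bearing ring with the five-atom dioxolane and raised the number, while a 1.6-fold lower number from compound 1 to compound 2 (0.19 log units; within the scatter) stayed within the scatter. Compound 4 `CCOC(CCSc1nc(-c2ccccc2)c(-c2ccccc2)[nH]1)OCC` carries 2,2-diethoxyethyl in place of 1,3-dioxolan-2-yl on a saturated chain carbon bound to a sulfur. For the measured compounds named here, no measured step tests an acyclic substituent here; the two bearing steps only show that a smaller group at this position weakened inhibition. A larger, open group is therefore expected to give a number no higher, possibly somewhat lower, a step of a 1.5-fold lower number from compound 3 to compound 4 (0.18 log units; within the scatter). Compound 4 is estimated at 350 nM, range 120 nM to 1000 nM.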

Compound 4, half-maximal inhibitory concentration: 69 nM
For compound 4 the middle estimate is 5.1-fold (0.71 log units) above the measured one; measured number outside the range, below it.
By their numbers in this assay, from the lowest: compounds 4, 2 and 1 (each within the scatter of the next, the first and the last beyond it); then compound 3.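

For the compounds shown here, open-chain 2,2-diethoxyethyl in place of 1,3-dioxolan-2-yl gives a 7.7-fold lower number from compound 3 to compound 4 (0.89 log units; beyond the scatter) in this assay, the first acyclic group at this place, and it more than makes up for what the smaller ring lost. Against the six-membered rings, a 1.3-fold lower number from compound 2 to compound 4 (0.12 log units; within the scatter) stays within the scatter and a 2.0-fold lower number from compound 1 to compound 4 (0.31 log units; beyond the scatter) lies beyond it, so no ring is needed on this saturated chain carbon bound to a sulfur. Nothing measured here explains the gain.

The change opens the ring and lengthens the chain together, and the compounds shown do not separate the two. A 3,3-dimethoxypropyl group, or an amine or a carboxylic acid on the chain, would show how far this tolerance reaches.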